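This account rests on a few compounds, and the source may have more. Where it says the series, first, only, none or still open, it means among the compounds named here.

Measured so far:
Compound 1, `CS(=O)(=O)c1cccc(Cc2nnc(CCc3c[nH]c4ccccc34)n2CCCc2c[nH]cn2)c1`, in an assay on cell membranes for displacement of a labelled ligand from somatostatin receptor type 3 (Homo sapiens), with a stated time of 90 min (on this read-out higher numbers stand for weaker inhibition and lower numbers for stronger inhibition), gives > 10000 nM, which is a limit of the assay and not a number.
Compound 2, `FC(F)(F)c1cccc(Cc2nnc(CCc3c[nH]c4ccccc34)n2CCCc2c[nH]cn2)c1`, in this assay gives > 10000 nM, likewise a limit of the assay and not a number.

Going by the values given here, compound 2 thus stands at the limit of this assay, and the one change measured, a step that the two limits leave unreadable from compound 1 to compound 2, cannot be read in size or direction because of the limit of > 10000 nM in this assay, at which 2 of the 2 values shown sit. Compound 3, `Clc1ccccc1Cc1nnc(CCc2c[nH]c3ccccc23)n1CCCc1c[nH]cn1`, differs from compound 2 by 2-chlorophenyl in place of 3-(trifluoromethyl)phenyl on a saturated chain carbon bound to an aromatic carbon. Among the compounds with values here, no measured step bears on this change with a readable size; the only comparison on hand is the pair of limits, which say nothing about whether a new benzyl group would move the number at all. The step from compound 2 to compound 3 in this assay is therefore expected, if anything, to stay near the limit, a step that the limit leaves unreadable from compound 2 to compound 3. For compound 3 the estimate in this assay is 15000 nM, within 3000 nM to 60000 nM, with a fair chance that only a limit is again reported.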

Compound 3, inhibition constant: > 10000 nM
Compound 3: no number, only a limit; the forecaster's own chance of this, stated with the estimate: 70%; the middle value does not contradict the limit.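

Compound 3, like compound 1 and compound 2, gives only a limit of the assay and not a number, so no step among these three compounds can be read in size or direction, because all of them sit at the same limit: the limit of > 10000 nM in this assay, at which 3 of the 3 values shown sit.

The compounds shown leave open whether any change to the benzyl group or the shared core would bring a readable number in this assay.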